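Adding a second hydroxymethyl to the weakest of three analogues

The source may hold more compounds than are shown below. What is called first, only, known or untested is meant among the compounds shown, and "the series" means these compounds.

Compound 3 `Cc1cc(CO)c2n1[C@@H](c1ccccc1)SC2` gives 29900 nM in a functional assay on MCF7 cells (Homo sapiens) for cytotoxicity, read by MTT assay, with a stated time of 72 h (a higher number here means a weaker inhibitor, a lower number a stronger inhibitor), the highest number of the three measured. Compound 1 `Cc1c(CO)cc2n1[C@@H](c1ccccc1)SC2`, which carries its hydroxymethyl elsewhere on the shared core, gives 2400 nM in this assay, and compound 2 `Cc1c(COC(=O)NCc2ccccc2)cc2n1[C@@H](c1ccccc1)SC2` gives 2200 nM; both gaps to compound 3 lie beyond the scatter. Compound 4 `Cc1c(CO)c(CO)c2n1[C@@H](c1ccccc1)SC2` is unmeasured; it differs from compound 3 by hydroxymethyl in place of hydrogen on an aromatic carbon, so it now carries the hydroxymethyl of compound 1 as well as that of compound 3. Because compound 1 gives 2400 nM, the added group is expected to bring the number down, with the step of a 6.0-fold lower number from compound 3 to compound 4 (0.78 log units; beyond the scatter) beyond the scatter. Compound 4 is therefore estimated at 5000 nM, within 1500 nM to 20000 nM.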

Compound 4, half-maximal inhibitory concentration: 1000 nM
For compound 4 the middle estimate is 5.0-fold (0.70 log units) above the measured one, outside the stated range (below it).
By their numbers in this assay, from the lowest: compound 4; then compounds 2 and 1 (each within the scatter of the next); then compound 3.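

In this assay, hydroxymethyl in place of hydrogen on this aromatic carbon gives a 30-fold lower number from compound 3 to compound 4 (1.48 log units; beyond the scatter), a large step, so this position can strongly change the reading. Added to the other aromatic carbon, the same group gives a 2.4-fold lower number from compound 1 to compound 4 (0.38 log units; beyond the scatter), a modest step that still lies beyond the scatter, so the size of the change depends on which hydroxymethyl is already present. Nothing shown here explains either step. On these data alone, whether an amine, a carboxylic acid or a longer chain at either carbon would lower the number further remains open. So does whether these steps would hold on other cells.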